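The source may report more compounds than this note shows. Statements on the series, on what has been measured and on what is new or still open speak of the compounds shown alone.

Measured so far in a functional assay (aorta) for inhibition, with Rattus norvegicus as the target; a lower number here means that less compound is needed, a higher number that more compound is needed for the effect:

compound 1, `O=C1C(Nc2ccc(F)cc2)=CC(=O)c2ncccc21`: 541 nM
compound 2, `O=C1C(Nc2ccc(F)cc2F)=CC(=O)c2ncccc21`: 288 nM
compound 3, `O=C1C=C(Nc2ccccc2)C(=O)c2cnccc21`: 439 nM

Compound 1 and compound 2 share a core and differ by a single change, (fluoro in place of hydrogen on an aromatic carbon), on an aromatic carbon; ortho to a large group; meta to a fluoro group. This gives a 1.9-fold lower number from compound 1 to compound 2 (0.27 log units; within the scatter). Compound 3 carries a different core; how the two cores differ is not broken down here. Its value in this assay lies close to that of compound 1, and the gap to compound 2 is also within the scatter, so no order among the three measured compounds can be read from these numbers.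

Compound 4, `O=C1C=C(Nc2cccc(F)c2)C(=O)c2cnccc21`, is not yet measured. It differs from compound 3 by fluoro in place of hydrogen on an aromatic carbon, on an aromatic carbon; meta to a large group. Within the data shown here, this is the same kind of change as the one from compound 1 to compound 2, but the surroundings of the place are not the same: there the entering fluoro stood ortho to a large group and meta to a fluoro group, here it stands meta to a large group, with no second fluoro present.

Among the measured compounds shown here, the only measured instance of this kind of change is a 1.9-fold lower number from compound 1 to compound 2 (0.27 log units; within the scatter), a step within the scatter. With that as the sole reference, and the surroundings not matching, the step from compound 3 to compound 4 is expected to be of similar or smaller size, a 1.4-fold lower number from compound 3 to compound 4 (0.14 log units; within the scatter). Compound 4 is therefore estimated at 320 nM, with a plausible range from 150 nM to 650 nM.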

Compound 4, half-maximal effective concentration: 562 nM
For compound 4 the middle estimate is 1.8-fold (0.24 log units) below the measured one; the measured number falls inside the stated range.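

In this assay, fluoro in place of hydrogen on an aromatic carbon of the core of compound 3 gives a 1.3-fold higher number from compound 3 to compound 4 (0.11 log units; within the scatter). Set beside the same change on the core of compound 1, the two steps cannot be told apart: the same change on two cores in this assay, a 1.9-fold lower number (0.27 log units; within the scatter) from compound 1 to compound 2 and a 1.3-fold higher number (0.11 log units; within the scatter) from compound 3 to compound 4, 2.4-fold (0.38 log units) apart, within the scatter of two such steps

This shows no measurable dependence of the change on the core, but it does not show that the change carries over from one core to the other, since neither step on its own stands clear of the scatter, the place of the entering fluoro is not the same in the two pairs, and two pairs give no direction or size that could be transferred to a further compound of the series.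

Still open is whether any replacement on the six-membered aromatic ring of carbon only moves the number beyond the scatter on either core, since the steps shown here involve only hydrogen and fluoro. As far as these compounds go, how a methoxy group, a nitrile, an amine or a carboxylic acid at the same place would compare with hydrogen, and whether such a step would be the same size on both cores, remains open.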